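A few compounds are considered here, and "the series" means these few. Any claim that something is new, unique, unknown or untested is made for them only; others in the source may bear on it.

Measured in a functional assay on MDA-MB-231 cells (Homo sapiens) for cytotoxicity, read by MTT assay, with a stated time of 72 h; on this read-out higher numbers stand for weaker inhibition and lower numbers for stronger inhibition:
- compound 1 `O=C1c2c[n+]([O-])c3ccccc3c2C(=O)c2c1c1ccccc1n2CCCCn1ccnc1`: 210 nM
- compound 2 `O=C1c2c[n+]([O-])c3ccccc3c2C(=O)c2c1c1ccccc1n2Cc1cn([C@@H]2C[C@H](O)[C@@H](CO)O2)nn1`: 130 nM
- compound 3 `CC1(C)OCC(Cn2cc(Cn3c4c(c5ccccc53)C(=O)c3c[n+]([O-])c5ccccc5c3C4=O)nn2)O1`: 230 nM

Compound 3 stands within the scatter of both other compounds, so the three values form one group. Compound 4 `CC1(C)OC[C@H](Cn2cc(Cn3c4c(c5ccccc53)C(=O)c3c[n+]([O-])c5ccccc5c3C4=O)nn2)O1` keeps the structure of compound 3: the two compounds have the same atoms and bonds; at least one stereo element is drawn with a configuration in one of them and without one in the other: 1 of 1 stereo elements differ; a stereocentre at a saturated ring carbon is drawn without a configuration in compound 3 and S in compound 4. Going by the values given here, no measured pair isolates a stereocentre. Among the compounds with values here, the only measured step that bears on the change is a 1.8-fold higher number from compound 2 to compound 3 (0.25 log units; within the scatter), and it replaces a whole substituent yet stays within the scatter. No step beyond the scatter is therefore expected in this assay, and no direction can be assigned. The expected step is a 1.0-fold lower number from compound 3 to compound 4 (0.02 log units; within the scatter). Compound 4 is estimated at 220 nM, with an expected range of 120 nM to 400 nM.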

Compound 4, half-maximal inhibitory concentration: 530 nM
Estimate against measurement, compound 4: 2.4-fold (0.38 log units) below; measured number above the stated range.
By their numbers in this assay, from the lowest: compounds 2, 1 and 3 (each within the scatter of the next); then compound 4.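

In this assay, going by these compounds alone, the S configuration drawn on the (2,2-dimethyl-1,3-dioxolan-4-yl)methyl group gives a 2.3-fold higher number from compound 3 to compound 4 (0.36 log units; beyond the scatter), the first step at this position to pass the scatter. The substituent replacement also passes it once the configuration is defined, with a 4.1-fold higher number from compound 2 to compound 4 (0.61 log units; beyond the scatter) as the step. The only structural difference behind the first step is stereochemical: the fact that one of compounds 3 and 4 is drawn with a defined configuration and the other without, at the place where they differ.

As far as these compounds go, the R configuration at this ring carbon remains open. So does whether a 2,3-dihydroxypropyl group on the aromatic nitrogen would read like compound 2 or compound 4.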